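A few compounds are considered here, and "the series" means these few. Any claim that something is new, unique, unknown or untested is made for them only; others in the source may bear on it.

Within the data shown here, in a functional assay on HaCaT cells (Homo sapiens) for inhibition, read by sulforhodamine B assay, with a stated time of 48 h (on this read-out lower numbers stand for stronger inhibition of growth and higher numbers for weaker inhibition of growth), compound 1 `COc1ccc(/C=C/C2(C)C=CC(=O)O2)c(OC)c1` gives 53600 nM, the lowest of the three numbers measured so far. Compound 2 `COc1ccc(/C=C/C2(C)C=CC(=O)O2)c(OC)c1OC` gives 217000 nM, and compound 3 `COc1cc(OC)c(OC)cc1/C=C/C1(C)C=CC(=O)O1` gives 180000 nM. Compound 4 `COc1cc(OC)c(/C=C/C2(C)C=CC(=O)O2)c(OC)c1` has not yet been measured. It differs from compound 1 by a single change, (methoxy in place of hydrogen on an aromatic carbon), which is methoxy in place of hydrogen on an aromatic carbon. Two measured steps make the same kind of swap: a 4.0-fold higher number from compound 1 to compound 2 (0.61 log units; beyond the scatter), and a 3.4-fold higher number from compound 1 to compound 3 (0.53 log units; beyond the scatter). Both are modest, and both point towards weaker inhibition of growth. A step of similar size in the same direction is therefore expected, and the estimated step is a 3.5-fold higher number from compound 1 to compound 4 (0.55 log units; beyond the scatter). The expected value for compound 4 is 190000 nM, within an estimated range of 90000 nM to 400000 nM.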

Compound 4, concentration for total growth inhibition: 458000 nM
Compound 4: the middle estimate sits 2.4-fold (0.38 log units) below what was measured, outside the stated range (above it).
By their numbers in this assay, from the lowest: compound 1; then compounds 3 and 2 (each within the scatter of the next); then compound 4.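

In this assay, methoxy in place of hydrogen at this position, ortho to a group of 9 heavy atoms and meta to two methoxy groups, gives an 8.5-fold higher number from compound 1 to compound 4 (0.93 log units; beyond the scatter) as the largest of the three steps seen for this swap. The same swap gives only a 4.0-fold higher number from compound 1 to compound 2 (0.61 log units; beyond the scatter) and a 3.4-fold higher number from compound 1 to compound 3 (0.53 log units; beyond the scatter) at the other places, so its size depends on where on the ring it is made. All three steps point towards weaker inhibition of growth, and compound 1 keeps the lowest number.

On these data alone, whether an amine or a hydroxyl at this position would give a similar step remains open. Nothing here shows why this position gives the largest step.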